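Extending the chain on a hydroxyphenyl chromone series

A few compounds are considered here, and "the series" means these few. Any claim that something is new, unique, unknown or untested is made for them only; others in the source may bear on it.

Measured so far:
compound 1, `CCCCCCOc1ccc2c(=O)c(-c3ccc(O)cc3)coc2c1`: 1500 nM
compound 2, `O=C(O)CCCCOc1ccc2c(=O)c(-c3ccc(O)cc3)coc2c1`: 100 nM
compound 3, `NCCCCOc1ccc2c(=O)c(-c3ccc(O)cc3)coc2c1`: 250 nM

In an assay (Cricetulus griseus) for inhibition of aldehyde dehydrogenase, mitochondrial (Homo sapiens) (on this read-out higher numbers stand for weaker inhibition and lower numbers for stronger inhibition), compound 3 stands second highest of the three, with compound 2 nearest below it and compound 1 furthest above it. The steps that frame it are a 2.5-fold higher number from compound 2 to compound 3 (0.40 log units; beyond the scatter) and a 6.0-fold lower number from compound 1 to compound 3 (0.78 log units; beyond the scatter).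

Compound 4, `O=c1c(-c2ccc(O)cc2)coc2cc(OCCCCCCCCCCCCO)ccc12`, has not yet been measured. It differs from compound 3 by 8-hydroxyoctyl in place of amino on a saturated chain carbon, four bonds along the chain from an oxygen on an aromatic ring. Among the compounds with values here, no measured step covers this exact change; the nearest guide is compound 1, where the same chain carbon carries ethyl, and the step of a 6.0-fold lower number from compound 1 to compound 3 (0.78 log units; beyond the scatter) shows that a plain hydrocarbon end gave the highest number of the three. Compound 4 keeps a hydrogen-bond donor at the chain end, as compound 2 and compound 3 do, but sets it far out on a long chain. The step of a 2.4-fold higher number from compound 3 to compound 4 (0.38 log units; beyond the scatter) is therefore expected to run toward a higher number, of modest size. For compound 4 the estimate in this assay is 600 nM, with a range from 200 nM to 2000 nM.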

Compound 4, half-maximal inhibitory concentration: 1700 nM
Estimate against measurement, compound 4: 2.8-fold (0.45 log units) below, within the range that was stated.
By their numbers in this assay, from the lowest: compound 2; then compound 3; then compounds 1 and 4 (each within the scatter of the next).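

In this assay, 8-hydroxyoctyl at this chain carbon did not keep the lower numbers seen with the carboxy and amino ends, giving a 6.8-fold higher number from compound 3 to compound 4 (0.83 log units; beyond the scatter) and a 17-fold higher number from compound 2 to compound 4 (1.23 log units; beyond the scatter). Compound 4 also shows that a hydroxyl-ended long chain need not differ from the hydrocarbon chain of compound 1, since the change of 6-hydroxyhexyl in place of hydrogen gives a 1.1-fold higher number from compound 1 to compound 4 (0.05 log units; within the scatter), so a hydrogen-bond donor at the chain end did not by itself go with a lower number here. Nothing available explains these differences.

Because chain length and end group change together from compound 3 to compound 4, the compounds shown do not separate their contributions. A hydroxyl on the shorter chain of compound 3, or an amine or a carboxylic acid on the longer chain of compound 4, would bear on that question.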